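This account rests on a few compounds, and the source may have more. Where it says the series, first, only, none or still open, it means among the compounds named here.

Working notes on the series. In a functional assay on DU-145 cells (Homo sapiens) for antiproliferative activity, read by MTT assay, with a stated time of 24 h (a lower number here means a stronger inhibitor, a higher number a weaker inhibitor), compound 1 `COc1cc(C(=O)/C=C/c2cc(-c3cc(OC)c(OC)c(OC)c3)n3nc(-c4ccccc4)cc3n2)cc(OC)c1OC` gives 34900 nM, the highest of the three numbers recorded. Compound 2 `COc1ccc(-c2cc(/C=C/C(=O)c3cc(OC)c(OC)c(OC)c3)nc3cc(-c4ccccc4)nn23)cc1OC` gives 8300 nM in this assay, and compound 3 `COc1ccc(-c2cc(C(=O)/C=C/c3cc(OC)c(OC)c(OC)c3)nc3cc(-c4ccccc4)nn23)cc1OC` gives 14700 nM; both sit below compound 1 by more than the scatter. Among the compounds with values here, the one step that changes a single place, a 4.2-fold lower number from compound 1 to compound 2 (0.62 log units; beyond the scatter), shows that dropping a methoxy from an aromatic carbon moved the number down modestly. Compound 4 `COc1cc(-c2cc(/C=C/C(=O)c3ccc(Cl)cc3)nc3cc(-c4ccccc4)nn23)cc(OC)c1OC` is not yet measured. Against compound 1 it differs by 4-chlorophenyl in place of 3,4,5-trimethoxyphenyl on a carbonyl carbon. Within the data shown here, no measured step bears directly on this change: the 3,4,5-trimethoxyphenyl leaves entirely, taking its three hydrogen-bond acceptors, and a 4-chlorophenyl with none enters, which is a larger alteration than any step seen so far. The only pointer is that the sole recorded removal of a methoxy lowered the number. Compound 4 is therefore expected to give 15000 nM, within 4000 nM to 60000 nM, a step of a 2.3-fold lower number from compound 1 to compound 4 (0.37 log units; beyond the scatter), with wide uncertainty in both directions.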

Compound 4, half-maximal inhibitory concentration: 29300 nM
Estimate against measurement, compound 4: 2.0-fold (0.29 log units) below; the range from low to high includes it.
By their numbers in this assay, from the lowest: compounds 2, 3, 4 and 1 (each within the scatter of the next, the first and the last beyond it).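

In this assay, 4-chlorophenyl in place of 3,4,5-trimethoxyphenyl on a carbonyl carbon gives a 1.2-fold lower number from compound 1 to compound 4 (0.08 log units; within the scatter), so compound 1 and compound 4 read alike at this position even though the whole aryl group changes and its hydrogen-bond acceptors leave. The removal of a single methoxy, by contrast, gave a 4.2-fold lower number from compound 1 to compound 2 (0.62 log units; beyond the scatter), so loss of methoxy groups does not by itself move the number beyond the scatter in this series. Nothing available explains why these two aryl groups read alike. Only these two aryl groups are shown on this carbonyl carbon. From the compounds shown here alone, it stays open whether an unsubstituted phenyl, or a phenyl carrying an amine or a carboxylic acid, would separate from them in this assay.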